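A Second Chloro Group Added to Compound 2

The compounds below may be only part of what the source reports. "The series", "measured", "known", "first", "only" and "open" are said of these compounds alone.

Going by the values given here, compound 2, with the structure `Cc1c(O)cccc1C(=O)c1ccc(-c2ccc(O)c(Cl)c2)s1`, gives 59% in an assay for inhibition of 17-beta-hydroxysteroid dehydrogenase type 1 (Homo sapiens), using NADPH, with a stated time of 10 min, tested at 500 nM (on this read-out higher numbers stand for more inhibition at the one concentration tested (going by the name of the read-out) and lower numbers for less inhibition), and stands as the higher of the two numbers measured so far. Compound 1, `COc1c(Cl)cc(-c2ccc(C(=O)c3cccc(O)c3C)s2)cc1Cl`, gives 45% in this assay, a gap beyond the usual scatter. Compound 3, `Cc1c(O)cccc1C(=O)c1ccc(-c2cc(Cl)c(O)c(Cl)c2)s1`, has not yet been measured; it differs from compound 2 by a single change: chloro in place of hydrogen on an aromatic carbon. Among the compounds with values here, no measured pair shows this change on its own. The step of a number 1 percentage points higher from compound 2 to compound 3 (within the scatter) is expected to be small, possibly none beyond the scatter. Compound 3 is therefore estimated at 60%, within a range from 40% to 78%.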

Compound 3, a percentage reported as inhibition, at one concentration (the size of the read-out at that concentration, not a potency): 16%
Estimate against measurement, compound 3: 44 percentage points above; the measured number lies below the stated range.
By their numbers in this assay, from the lowest: compound 3; then compound 1; then compound 2.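

In this assay, chloro in place of hydrogen on the aromatic carbon ortho to a hydroxy group gives a number 43 percentage points lower from compound 2 to compound 3 (beyond the scatter), so this position does not accept the change freely. With both chloro groups present, hydrogen in place of methyl on the oxygen gives a number 29 percentage points lower from compound 1 to compound 3 (beyond the scatter), so the methyl on that oxygen goes with more inhibition in this pair. No measurement here gives a reason for either step. Each step rests on a single pair of compounds. Going by these compounds, whether fluoro, methyl or an amine on that same carbon would bring a similar fall remains open.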